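A Methoxy Group Added to the Ring of Compound 2

This account rests on a few compounds, and the source may have more. Where it says the series, first, only, none or still open, it means among the compounds named here.

Of the compounds shown here, three have so far been tested in an assay on BTI cells for inhibition of Amine oxidase [flavin-containing] A (Homo sapiens), read by fluorescence, with a stated time of 20 min, tested at 1 uM; a lower number here means less inhibition, a higher number more inhibition at the concentration tested (going by the name of the read-out). Compound 2 `CC1(C)COc2ccccc2C1O`, an alcohol on a two-ring core, gives 24.3%, the highest of the three numbers. Compound 3 `C#CCN(Cc1ccccc1)C1c2cccc(OC)c2OCC1(C)C`, which carries a methoxy group on its aromatic ring and a substituted amine in place of the alcohol, gives 4.3%, a number beyond the scatter below that of compound 2. Compound 1 `COc1cccc2c1OCC(C)(C)C2N`, a primary amine that also bears a methoxy group on its aromatic ring, gives -0.7%, further still below compound 2. No two of these compounds differ in only one place, so no single step can be read off directly.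

Compound 4 `COc1cccc2c1C(O)C(C)(C)CO2` is the untested compound that follows from compound 2 by one change: methoxy in place of hydrogen on an aromatic carbon. Both compounds already measured that carry this methoxy group, compound 1 and compound 3, sit near zero in this assay, although they differ from compound 2 in more than this one place. On that basis a step downward beyond the scatter is expected, from compound 2 to compound 4 in this assay of a number 16.3 percentage points lower from compound 2 to compound 4 (beyond the scatter). Compound 4 is therefore estimated to give about 8%, within a range of -8% to 24%.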

Compound 4, a percentage reported as inhibition, at one concentration (the size of the read-out at that concentration, not a potency): 11.5%
For compound 4 the middle estimate is 3.5 percentage points below the measured one, and the stated range covers the measured number.
By their numbers in this assay, from the lowest: compounds 1, 3 and 4 (each within the scatter of the next, the first and the last beyond it); then compound 2.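

With the alcohol and the rest of the core unchanged, methoxy in place of hydrogen on this aromatic carbon, ortho to a fused ring and meta to a fused ring, gives in this assay a number 12.8 percentage points lower from compound 2 to compound 4 (beyond the scatter) as a modest step. Among the compounds shown here, this is the first reading of the methoxy change on its own, since no two of the earlier compounds differed in only one place. No measurement at hand gives a reason for this step.

As far as these compounds go, whether an ethoxy group or a chlorine atom on this same aromatic carbon would move the number as methoxy does stays open. So does whether methoxy in place of hydrogen gives a step of similar size when an amine stands in place of the alcohol.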